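Carbonyl substituent swap from compound 2 to compound 3

A few compounds are considered here, and "the series" means these few. Any claim that something is new, unique, unknown or untested is made for them only; others in the source may bear on it.

In a functional assay on HepG2 cells (Homo sapiens), read by MTT assay, with a stated time of 48 h (a lower number here means a stronger inhibitor, a higher number a weaker inhibitor), compound 1 (`CCn1c(C(=O)NCCN)ccc1C(CC)(CC)c1ccc(OCC(O)C(C)(C)C)c(C)c1`) gives 176 nM and compound 2 (`CC[C@@H](C)[C@H](NC(=O)c1ccc(C(CC)(CC)c2ccc(OCC(O)C(C)(C)C)c(C)c2)n1CC)C(=O)O`) gives 127 nM. Going by the values given here, these are the only two numbers, and compound 2 stands level with compound 1 within the scatter. Among the compounds with values here, the one measured step, a 1.4-fold lower number from compound 1 to compound 2 (0.14 log units; within the scatter), exchanges 2-aminoethyl for 1-carboxy-2-methylbutyl on the amide nitrogen and stays within the scatter.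

Compound 3 (`CCn1c(C(=O)Oc2ccc(CCO)cc2)ccc1C(CC)(CC)c1ccc(OCC(O)C(C)(C)C)c(C)c1`) keeps the shared core and changes the group on the carbonyl carbon: a group of 10 heavy atoms (8 carbon, 2 oxygen; one six-membered aromatic ring of carbon only) in place of a group of 9 heavy atoms (6 carbon, 1 nitrogen, 2 oxygen; no ring), on a carbonyl carbon. Within the data shown here, no measured compound carries a six-membered aromatic ring of carbon only in that place, so the data do not cover this change directly. Among the measured compounds shown here, the only guide is the measured step of a 1.4-fold lower number from compound 1 to compound 2 (0.14 log units; within the scatter), a different exchange at the same end of the molecule, which points to no direction. No step beyond the scatter is therefore expected, though with low confidence. The expected change is a 1.2-fold higher number from compound 2 to compound 3 (0.07 log units; within the scatter). Compound 3 is estimated at 150 nM, with an expected range of 50 nM to 450 nM.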

Compound 3, half-maximal inhibitory concentration: > 50000 nM
Compound 3: no number, only a limit (the forecaster's own chance of this, stated with the estimate: 3%); at least 330-fold (2.52 log units) between middle value and limit.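

In this assay compound 3 returns only a limit, not a number: the limit of > 50000 nM in this assay, at which 1 of the 3 values shown sits. Against the two earlier groups the new one gives an at least 390-fold higher number from compound 2 to compound 3 (2.59 log units; beyond the scatter) and an at least 280-fold higher number from compound 1 to compound 3 (2.45 log units; beyond the scatter), whereas the only earlier step, a 1.4-fold lower number from compound 1 to compound 2 (0.14 log units; within the scatter), had shown the position on the carbonyl carbon tolerating a large exchange of groups with no change beyond the scatter. That tolerance therefore does not extend to every group at this place: both groups on an amide-type nitrogen keep a value in the same range, while the entering group, with its six-membered aromatic ring of carbon only and no nitrogen, falls away sharply.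

The ring arrives and the amide-type nitrogen leaves in the same step, so the compounds shown cannot say which of the two changes carries the loss, and a phenyl ring on an amide-type nitrogen would separate them. Equally open, going by these compounds, is whether a simple carboxylic acid or a longer amine chain on that nitrogen would stay level with compound 1 and compound 2, and the true size of the step remains unknown behind the limit.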